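The source may report more compounds than this note shows. Statements on the series, on what has been measured and on what is new or still open speak of the compounds shown alone.

Measured compounds:
Compound 1, `Fc1ccc(C2CC(c3ccccc3)=NN2c2ccc(-c3ccccc3)nn2)cc1`: 8420 nM
Compound 2, `COc1ccc(C2=NN(c3ccc(-c4ccccc4)nn3)C(c3ccc(Cl)cc3)C2)cc1`: > 100000 nM

Compound 2 was tested in a functional assay on HepG2 cells (Homo sapiens) for antiproliferative activity, read by MTT assay, with a stated time of 24 h; a lower number here means a stronger inhibitor, a higher number a weaker inhibitor. For compound 2 the result is only a limit of the assay, > 100000 nM, the point named in the limit of > 100000 nM in this assay, at which 1 of the 2 values shown sits. In this assay, within the data shown here, compound 1 gave 8420 nM; it carries fluorine where compound 2 carries chlorine and a plain phenyl where compound 2 carries a methoxyphenyl, so the two compounds differ in two places and no single step links them. Compound 3, `COc1ccc(C2=NN(c3ccc(-c4ccccc4)nn3)C(c3ccc(F)cc3)C2)cc1`, arises from compound 2 by a single change: fluoro in place of chloro on an aromatic carbon. Among the measured compounds shown here, no measured pair with this single change is available. With compound 2 at a limit, compound 3 is expected to shift by an at least 2.0-fold lower number from compound 2 to compound 3 (0.30 log units; that floor lies within the scatter), a step toward stronger inhibition whose size is uncertain. Compound 3 is estimated at 50000 nM, with a range from 8000 nM to 300000 nM.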

Compound 3, half-maximal inhibitory concentration: 9160 nM
The estimate for compound 3 lay 5.5-fold (0.74 log units) above the measured number, and the stated range covers the measured number.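

In this assay, fluoro in place of chloro on this aromatic carbon, para to a large group, gives an at least 10-fold lower number from compound 2 to compound 3 (1.03 log units; beyond the scatter), so at this position the choice between the two halogens separates a compound with a measured number from one without. The result for compound 2 is only a limit of the assay, which leaves this step with a floor and no upper bound: the limit of > 100000 nM in this assay, at which 1 of the 3 values shown sits. With the 4-fluorophenyl group in place, methoxy in place of hydrogen on an aromatic carbon gives a 1.1-fold higher number from compound 1 to compound 3 (0.04 log units; within the scatter), so on this background that second change does not move the number beyond the scatter.

The compounds shown leave open whether a bromo group or an amine at this position would read like fluoro or like chloro. They also leave open whether the 4-chlorophenyl to 4-fluorophenyl step has the same size with the plain phenyl of compound 1.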